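A few compounds are considered here, and "the series" means these few. Any claim that something is new, unique, unknown or untested is made for them only; others in the source may bear on it.

Going by the values given here, in an ADME assay on microsomes from liver (Homo sapiens) for metabolic stability, read by LC-MS, using NADPH, with a stated time of 10 min, tested at 0.5 uM (a lower number here means that less of the compound is left, a higher number that more of the compound is left), compound 1 (`COC(=O)Nc1cc(-c2cnc(OC[C@@](C)(N)CC(C)C)c(Cl)c2)ccn1`) gives 90% and compound 2 (`CC(=O)Nc1cc(-c2ccc(OC[C@@H](N)CC(C)C)c(Cl)c2)ccn1`) gives 89% and these two numbers lie within the scatter of each other, so compound 1 stands level with the only other measured compound. Compound 3 (`COC(=O)Nc1cc(-c2cnc(OC[C@@](C)(N)CC(C)C)c(C#N)c2)ccn1`) keeps the core of compound 1 and carries cyano in place of chloro on an aromatic carbon, ortho to a (2-amino-2,4-dimethylpentyl)oxy group (cyano in place of chloro on an aromatic carbon). Among the compounds with values here, the series offers no measured step between compounds that differ in one place, so no measured step sizes this change. Within the data shown here, the only starting point is compound 1 at 90% as the reference. The estimated step is a number 3 percentage points lower from compound 1 to compound 3 (within the scatter) in this assay and it is expected to be small, slightly downward and within the scatter. For compound 3 the expected value is 87% with an estimated range from 74% to 96% for repeat measurements.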

Compound 3, percent of the compound remaining: 95%
The estimate for compound 3 lay 8 percentage points below the measured number, and the stated range covers the measured number.
By their numbers in this assay, from the lowest: compounds 2, 1 and 3 (each within the scatter of the next).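

Working from this assay, the series now has its first step between compounds that differ in one place: a number 5 percentage points higher from compound 1 to compound 3 (within the scatter). On the aromatic carbon ortho to the (2-amino-2,4-dimethylpentyl)oxy group, two atoms from the ring nitrogen, cyano therefore stands level with chloro, and this one pair shows no separation between the two groups. Nothing available explains the step or ties it to any property of either group.

Still open, on these data alone, is how other groups at this position would read, such as fluoro, methyl or methoxy, and whether a single pair is a fair guide to this place at all. Equally open, as far as these compounds go, is whether the cyano for chloro exchange would read the same with a urea in place of the methyl carbamate on the shared core.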